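Aryl amide series: pyrazolyl in place of piperidinyl

The compounds below may be only part of what the source reports. "The series", "measured", "known", "first", "only" and "open" are said of these compounds alone.

Three compounds on one shared core have numbers in an assay on HeLa cells for binding affinity to Vasopressin V2 receptor (Homo sapiens); on this read-out higher numbers stand for weaker inhibition and lower numbers for stronger inhibition. Compound 1 `CNc1ccc(C(=O)N2CCCCc3ccccc32)c(Cl)c1` gives 35 nM. Compound 2 `CN(C)c1ccc(C(=O)N2CCCCc3ccccc32)c(Cl)c1` gives 18 nM, and the step of a 1.9-fold lower number from compound 1 to compound 2 (0.29 log units; within the scatter). Compound 3 `O=C(c1ccc(N2CCCCC2)cc1Cl)N1CCCCc2ccccc21` gives 120 nM, the highest of the three numbers and the only one beyond the scatter from the other two.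

Compound 4 `Cc1ccn(-c2ccc(C(=O)N3CCCCc4ccccc43)c(Cl)c2)n1` is not yet measured. The change from compound 3: 3-methyl-1H-pyrazol-1-yl in place of piperidin-1-yl on an aromatic carbon. Among the measured compounds shown here, the steps that bear on it are a 3.4-fold higher number from compound 1 to compound 3 (0.54 log units; beyond the scatter) and a 6.7-fold higher number from compound 2 to compound 3 (0.82 log units; beyond the scatter), both showing that the six-membered non-aromatic ring gives a higher number than the two small nitrogen substituents. For the measured compounds named here, no measured step swaps a saturated ring for an aromatic one on this carbon, so the direction of the new step rests on the ring in compound 3 being the weakest position so far. A modest lowering is expected, with wide uncertainty: a 2.0-fold lower number from compound 3 to compound 4 (0.30 log units; within the scatter). Compound 4 is estimated at 60 nM, in the range 15 nM to 250 nM.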

Compound 4, half-maximal inhibitory concentration: 13 nM
Compound 4: the middle estimate sits 4.6-fold (0.66 log units) above what was measured; measured number outside the range, below it.
By their numbers in this assay, from the lowest: compounds 4, 2 and 1 (each within the scatter of the next, the first and the last beyond it); then compound 3.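

At this aromatic carbon, meta to a chloro group, a ring substituent as such does not carry a high number in this assay: the change from piperidin-1-yl to 3-methyl-1H-pyrazol-1-yl, two groups with the same count of heavy atoms, gives (a 9.2-fold lower number from compound 3 to compound 4 (0.97 log units; beyond the scatter)). The high number of compound 3 thus goes with the six-membered non-aromatic ring, while the five-membered aromatic ring stands level with dimethylamino (a 1.4-fold lower number from compound 2 to compound 4 (0.14 log units; within the scatter)) and gives a lower number than methylamino (a 2.7-fold lower number from compound 1 to compound 4 (0.43 log units; beyond the scatter)). Nothing available explains the difference between the two rings.

As far as these compounds go, it remains open whether the methyl group of compound 4 contributes to its number, or whether the aromatic ring alone is enough. Unsubstituted pyrazol-1-yl, phenyl and morpholin-4-yl at this carbon would separate these contributions.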